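Chlorine Added to the Benzylsulfanyl Ring of Compound 2

A few compounds are considered here, and "the series" means these few. Any claim that something is new, unique, unknown or untested is made for them only; others in the source may bear on it.

Compound 1 `Cc1cc(S(=O)(=O)/N=C(\N)N/N=C/C#Cc2ccccc2)c(SCc2ccccc2)cc1Cl`: 8000 nM
Compound 2 `C/C(C#Cc1ccccc1)=N\N/C(N)=N/S(=O)(=O)c1cc(C)c(Cl)cc1SCc1ccccc1`: 10000 nM
Compound 3 `Cc1cc(S(=O)(=O)/N=C(\N)N/N=C/C#Cc2ccccc2)c(SCc2ccccc2Cl)cc1Cl`: 27000 nM

All three were measured in a functional assay on HCT-116 cells (Homo sapiens) for antiproliferative activity, read by MTT assay, with a stated time of 72 h; on this read-out lower numbers stand for stronger inhibition and higher numbers for weaker inhibition. Compound 2 stands second highest of the three numbers. Its nearest neighbour is compound 1, the step being a 1.3-fold higher number from compound 1 to compound 2 (0.10 log units; within the scatter), so these two cannot be ordered. Compound 3 lies furthest from compound 2, and compound 3 differs from compound 1 by a 3.4-fold higher number from compound 1 to compound 3 (0.53 log units; beyond the scatter).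

Compound 4 `C/C(C#Cc1ccccc1)=N\N/C(N)=N/S(=O)(=O)c1cc(C)c(Cl)cc1SCc1cccc(Cl)c1` has not yet been measured in this assay. It differs from compound 2 by chloro in place of hydrogen on an aromatic carbon. Among the compounds with values here, one measured step bears on this: the one from compound 1 to compound 3 is also chloro in place of hydrogen on an aromatic carbon of the benzylsulfanyl ring, and it gave a 3.4-fold higher number from compound 1 to compound 3 (0.53 log units; beyond the scatter). The chlorine in compound 4 enters the same ring, so a step of similar kind is expected here, modest but beyond the scatter and toward higher numbers, estimated as a 2.5-fold higher number from compound 2 to compound 4 (0.40 log units; beyond the scatter). Compound 4 is therefore expected to give about 25000 nM, with a range from 10000 nM to 60000 nM.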

Compound 4, half-maximal inhibitory concentration: 119000 nM
Estimate against measurement, compound 4: 4.8-fold (0.68 log units) below, outside the stated range (above it).
By their numbers in this assay, from the lowest: compounds 1 and 2 (each within the scatter of the next); then compound 3; then compound 4.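

In this assay, the (3-chlorobenzyl)sulfanyl group of compound 4 gives a 12-fold higher number from compound 2 to compound 4 (1.08 log units; beyond the scatter), a large step toward weaker inhibition. Within the data shown here, this shows that chloro on the benzylsulfanyl ring has no single size of effect, which the one earlier step could not reveal: both steps run toward higher numbers, but their sizes differ clearly: the same change on two cores in this assay, a 3.4-fold higher number (0.53 log units; beyond the scatter) from compound 1 to compound 3 and a 12-fold higher number (1.08 log units; beyond the scatter) from compound 2 to compound 4, 3.5-fold (0.55 log units) apart, beyond the scatter of two such steps. The starting points of these two steps, compound 1 and compound 2, lie within the scatter of each other, so the two cores read alike without the added chloro and part company only once it is present.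

What the compounds shown leave open is whether the larger step belongs to the core or to the ring carbon that carries the chloro, as the chlorine of compound 3 and that of compound 4 sit at different carbons of the ring and the two steps therefore differ in both respects. They also do not tell whether a fluoro, a methoxy or an amine on the same carbon of the ring of compound 2 would move the number as far as chloro does.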